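Pyrimidin-5-yl for pyridin-3-yl on compound 2

The compounds below may be only part of what the source reports. "The series", "measured", "known", "first", "only" and "open" are said of these compounds alone.

In an ADME assay on L02 cells (Homo sapiens) for cytotoxicity, read by CCK-8 assay, with a stated time of 6 days (on this read-out higher numbers stand for weaker inhibition and lower numbers for stronger inhibition), compound 1 `C[C@@H](Cn1ccc(-c2ccc(C#N)c(Cl)c2)n1)NS(=O)(=O)c1cccnc1` is recorded as "not determined" (no result reported). Compound 2 `C[C@@H](Cn1ccc(-c2ccc(C#N)c(Cl)c2)n1)Nc1cccnc1` reads > 30000 nM, which is a limit of the assay and not a number. Within the data shown here, no measured step is therefore available. Compound 3 `C[C@@H](Cn1ccc(-c2ccc(C#N)c(Cl)c2)n1)Nc1cncnc1` carries pyrimidin-5-yl in place of pyridin-3-yl on an amine nitrogen. The expected step of a number no higher from compound 2 to compound 3 (the limit leaves the size open) is none beyond the scatter in this assay, with no direction favoured. For compound 3 the estimated value is 30000 nM, with an expected range of 15000 nM to 60000 nM.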

Compound 3, half-maximal inhibitory concentration: > 30000 nM
Compound 3: only a limit was reported (the forecaster's own chance of this, stated with the estimate: 80%); the middle value sits exactly at the limit.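

No step can be read from compound 2 to compound 3: both values in this assay are limits and not numbers. The compounds shown leave open whether pyrimidin-5-yl in place of pyridin-3-yl on an amine nitrogen shifts the read-out at all.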